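A few compounds are considered here, and "the series" means these few. Any claim that something is new, unique, unknown or untested is made for them only; others in the source may bear on it.

Measured compounds in a functional assay, read by HPLC, with a stated time of 15 min; on this read-out lower numbers stand for stronger inhibition and higher numbers for weaker inhibition:
compound 1 `CN(C)/C=C/C(=O)c1nn(-c2ccccc2)cc1C(=O)c1ccccc1` gives 44000 nM
compound 2 `Cc1ccc(-n2cc(C(=O)c3ccccc3)c(C(=O)/C=C/N(C)C)n2)cc1` gives 34200 nM

Compound 1 has the highest of the two numbers in this assay; its nearest neighbour is compound 2, and the step of a 1.3-fold lower number from compound 1 to compound 2 (0.11 log units; within the scatter) is within the scatter, so the two cannot be ordered.

The next compound, compound 3 `CC(=O)c1nn(-c2ccccc2)cc1C(=O)c1ccccc1`, departs from compound 1 at the carbonyl carbon whose other neighbour is an aromatic carbon: methyl in place of 2-(dimethylamino)ethenyl on a carbonyl carbon. Cut one bond further out, the change reads as (2-(dimethylamino)ethenyl)carbonyl to acetyl.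

Among the measured compounds shown here, no measured step bears on this change. For the measured compounds named here, the only step in hand, from compound 1 to compound 2, alters a different place, a methyl in place of hydrogen on an aromatic carbon, and it stays within the scatter; it says nothing about removing the 2-(dimethylamino)ethenyl group. Both measured compounds are weak in this assay, and the loss of the larger group gives no ground to expect a gain. The expectation is therefore a number near that of compound 1 or somewhat higher, with wide uncertainty, and a step of a 1.4-fold higher number from compound 1 to compound 3 (0.13 log units; within the scatter) is expected. For compound 3 the estimate is 60000 nM, with a range from 15000 nM to 200000 nM.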

Compound 3, half-maximal inhibitory concentration: 39500 nM
Compound 3: the middle estimate sits 1.5-fold (0.18 log units) above what was measured; the range from low to high includes it.
By their numbers in this assay, from the lowest: compounds 2, 3 and 1 (each within the scatter of the next).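

In this assay, among the compounds shown here, methyl in place of 2-(dimethylamino)ethenyl on a carbonyl carbon gives a 1.1-fold lower number from compound 1 to compound 3 (0.05 log units; within the scatter) and so cannot be told apart from the parent compound, which gives this position its only reading so far. The whole 2-(dimethylamino)ethenyl group, with its nitrogen and its double bond outside aromatic rings, can therefore leave this carbonyl carbon without a step beyond the scatter, and the number of compound 3 stays in the same range as that of compound 1. Nothing in hand gives a reason for this result.

On these data alone, whether any group on this carbonyl carbon can move the number beyond the scatter of compound 1 stays open, for instance a carboxylic acid, a primary amine or a longer alkyl chain in place of the methyl. Also open, as far as these compounds go, is whether the methyl in place of hydrogen on an aromatic carbon, which separates compound 2 from compound 1, would read the same on the acetyl compound, compound 3, as it does on the compound carrying 2-(dimethylamino)ethenyl.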